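This account rests on a few compounds, and the source may have more. Where it says the series, first, only, none or still open, it means among the compounds named here.

In an ADME assay on MT4 cells (Homo sapiens) for cytotoxicity, read by MTT assay, with a stated time of 4 days (on this read-out lower numbers stand for higher toxicity in this test and higher numbers for lower toxicity in this test), compound 1 `Cc1ccc(-c2c(C)c(-c3ccc4c(c3)CCO4)c(C(OC(C)(C)C)C(=O)O)c(C)c2NS(C)(=O)=O)cc1C` gives 38000 nM. Two relatives sit close to it: compound 2 `CNC(=O)Nc1c(C)c(C(OC(C)(C)C)C(=O)O)c(-c2ccc(C)c(C)c2)c(C)c1-c1ccc(C)c(C)c1` gives 20000 nM, and compound 3 `CC(=O)Nc1c(C)c(C(OC(C)(C)C)C(=O)O)c(-c2ccc(C)c(C)c2)c(C)c1-c1ccc(C)c(C)c1` gives 19000 nM. All three values lie within the usual scatter of one another, so compound 1 stands level with the other two.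

Compound 4 `Cc1ccc(-c2c(C)c(-c3ccc(Cl)c(F)c3)c(C(OC(C)(C)C)C(=O)O)c(C)c2NS(C)(=O)=O)cc1C` keeps the core of compound 1 and exchanges one group: a group of 8 heavy atoms (6 carbon, 1 fluorine, 1 chlorine; one six-membered aromatic ring of carbon only) in place of a group of 9 heavy atoms (8 carbon, 1 oxygen; one five-membered non-aromatic ring with 1 hetero atom, one six-membered aromatic ring of carbon only), on an aromatic carbon. The 4-chloro-3-fluorophenyl group sits para to the methanesulfonamido group. For the measured compounds named here, no measured pair makes this exchange. Going by the values given here, the only single-place step available is a 1.1-fold lower number from compound 2 to compound 3 (0.02 log units; within the scatter), which lies within the scatter but concerns a carbonyl carbon, not this position, so it bears on the question only indirectly.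

A little more comes from compound 3, which carries a 3,4-dimethylphenyl group at this same place and also differs from compound 1 in a second place. Compound 3 gives 19000 nM, still within the scatter of compound 1. On this thin evidence, no change beyond the scatter is expected in this assay. The expected step is a 1.4-fold lower number from compound 1 to compound 4 (0.13 log units; within the scatter), which would place compound 4 among the three measured values. For compound 4 the estimated value is 28000 nM, with an expected range of 12000 nM to 60000 nM.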

Compound 4, half-maximal cytotoxic concentration: 22000 nM
Beside the measured number, compound 4's estimate is 1.3-fold (0.10 log units) above it; low and high end bracket the measured number.
By their numbers in this assay, from the lowest: compounds 3, 2, 4 and 1 (each within the scatter of the next).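

For the compounds shown here, this is the first pair of compounds that differs in this one place only, the aromatic carbon para to the methanesulfonamido group. In this assay, replacing the oxygen-containing group with its five-membered non-aromatic ring by 4-chloro-3-fluorophenyl gives a 1.7-fold lower number from compound 1 to compound 4 (0.24 log units; within the scatter), so the two compounds cannot be told apart in this test. At this place and on this core, then, losing the non-aromatic ring and its oxygen while gaining chlorine and fluorine leaves the cytotoxicity read-out within the normal noise of repeated measurements, and no measurement of any property of the two groups is available to explain this result.

Every group shown at this place is an uncharged aromatic ring with no net charge, so it remains open whether an amine, a carboxylic acid or a longer alkyl chain attached here would also leave the number within the scatter. Only this one cell test is shown, so the effect of the exchange on any other measure of the compounds also remains open.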